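A few compounds are considered here, and "the series" means these few. Any claim that something is new, unique, unknown or untested is made for them only; others in the source may bear on it.

Compound 1 `c1ccc2c(c1)CN[C@@H](CN(CC1CCNCC1)[C@H]1CCCc3cccnc31)C2` gives 65 nM in a functional assay on CCRF-CEM cells for antagonist activity at C-X-C chemokine receptor type 4 (Homo sapiens), read by calcium flux, with stated times of 25 min and 90 s; a lower number here means a stronger inhibitor, a higher number a weaker inhibitor.
Compound 2 `CN1CCN(CCCN(C[C@H]2Cc3ccccc3CN2C)[C@H]2CCCc3cccnc32)CC1` gives 536 nM in this assay.

Of these two compounds, compound 1 stands at the lowest number, and compound 2 sits well beyond the usual scatter above it. Compound 1 and compound 2 differ in more than one place, so their gap cannot be laid at the door of a single change.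

Compound 3 `CCN1CCN(CCCN(C[C@H]2Cc3ccccc3CN2)[C@H]2CCCc3cccnc32)CC1` has not yet been measured in this assay. Compared with compound 1 the change is 2-(4-ethylpiperazin-1-yl)ethyl in place of piperidin-4-yl on a saturated chain carbon bound to an amine nitrogen. Compound 2, which carries a chain of a related kind together with other changes, gives the weaker number of the two measured compounds, and this is the only pointer available. The step from compound 1 to compound 3 is therefore expected to be a moderate rise in the number, a 2.5-fold higher number from compound 1 to compound 3 (0.39 log units; beyond the scatter). Compound 3 is expected to give about 160 nM, with a likely range from 55 nM to 500 nM.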

Compound 3, half-maximal inhibitory concentration: 33 nM
Compound 3: middle estimate off by 4.8-fold (0.69 log units), on the high side; measured number below the stated range.
By their numbers in this assay, from the lowest: compounds 3 and 1 (each within the scatter of the next); then compound 2.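

In this assay, going by these compounds alone, the single change of side group gives a 2.0-fold lower number from compound 1 to compound 3 (0.29 log units; within the scatter), so the two numbers cannot be told apart. This place on the core therefore accepts a group of 10 heavy atoms with 0 hydrogen-bond donors where one of 6 heavy atoms with 1 donor stood, and the number stays within the usual scatter. Nothing measured here explains why these two different groups give such similar numbers.

The ring and the chain length change together in this one step, so the compounds shown leave open what each contributes alone. A plain 3-aminopropyl chain or a 3-(morpholin-4-yl)propyl group at the same place would begin to separate the two.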